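Cyano in place of hydrogen on compound 1

The compounds below may be only part of what the source reports. "The series", "measured", "known", "first", "only" and "open" are said of these compounds alone.

Compound 1 (`Cc1cc(O)c(C(=O)/C=C/c2ccccc2)c(=O)o1`) is the starting point for this comparison. In a functional assay on HCT-116 cells (Homo sapiens) for cytotoxicity, read by MTT assay (a lower number here means a stronger inhibitor, a higher number a weaker inhibitor), compound 1 gives > 100000 nM, which is a limit of the assay and not a number. In this assay compound 2 (`Cc1cc(O)c(C(=O)/C=C/c2cccc(Cl)c2)c(=O)o1`) gives 66400 nM.

The next compound to be read is compound 3 (`Cc1cc(O)c(C(=O)/C=C/c2ccc(C#N)cc2)c(=O)o1`), which differs from compound 1 by cyano in place of hydrogen on an aromatic carbon, para to a large group. Among the measured compounds shown here, only one measured step bears on this change: an at least 1.5-fold lower number from compound 1 to compound 2 (0.17 log units; that floor lies within the scatter), where chloro takes the place of hydrogen on an aromatic carbon. That is a single step with a different group, and its size is known only as a floor. For the measured compounds named here, no step clearly beyond the scatter can therefore be expected in this assay. If the number moves, the expected direction is downward, as the reading for compound 2 of 66400 nM suggests. The expected step is an at least 1.4-fold lower number from compound 1 to compound 3 (0.15 log units; that floor lies within the scatter). For compound 3 the estimated value is 70000 nM, with an expected range from 30000 nM to 150000 nM. A report of a limit alone remains quite possible.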

Compound 3, half-maximal inhibitory concentration: 66000 nM
For compound 3 the middle estimate is 1.1-fold (0.03 log units) above the measured one; the measured number falls inside the stated range.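

In this assay, cyano in place of hydrogen on an aromatic carbon, para to a large group, adds a reading at a second substituted place on the ring and gives an at least 1.5-fold lower number from compound 1 to compound 3 (0.18 log units; that floor lies within the scatter). This step is only a floor, and that floor lies within the scatter, so neither this position nor this change is shown to give a real gain in potency over hydrogen, although compound 3 does give a number rather than a limit. The true size of the step cannot be read because compound 1 stands at a limit of the assay and not at a number: the limit of > 100000 nM in this assay, at which 1 of the 3 values shown sits.

Compound 2 and compound 3 differ in both the group and its place, so they do not separate the effect of the group from that of the position, which a chloro on this same aromatic carbon would begin to do. From the compounds shown here alone, it also remains open whether an amine, a carboxylic acid or a longer chain at this position would give a step clearly beyond the scatter in this assay.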